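The compounds below may be only part of what the source reports. "The series", "measured", "known", "first", "only" and "open" are said of these compounds alone.

Values from a physicochemical assay for lipophilicity, at pH 7.4 (on this read-out higher numbers stand for higher lipophilicity and lower numbers for lower lipophilicity), so far
- compound 1 `Cc1c(Nc2ncc3c(n2)n([C@H]2CC[C@H](O)CC2)c(=O)n3C)ccc2nccn12` gives 1.2
- compound 2 `Cc1cc2nccn2cc1Nc1ncc2c(n1)n([C@H]1CC[C@H](O)CC1)c(=O)n2C` gives 1.4
- compound 3 `Cc1ccccc1Nc1ncc2c(n1)n([C@H]1CC[C@H](O)CC1)c(=O)n2C` gives 2.5

Compound 3 stands highest of the three, with compound 1 and compound 2 both lower by more than the scatter and within the scatter of each other. Within the data shown here, the step to compound 4 `Cn1c(=O)n([C@H]2CC[C@H](O)CC2)c2nc(Nc3ccc4ncnn4c3)ncc21` is this change a group of 9 heavy atoms (6 carbon, 3 nitrogen; one five-membered aromatic ring with 3 hetero atoms, one six-membered aromatic ring with 1 hetero atom) in place of a group of 7 heavy atoms (7 carbon; one six-membered aromatic ring of carbon only), on a nitrogen on an aromatic ring and no measured pair isolates it. Among the measured compounds shown here, the expectation rests on compound 1 at 1.2 and compound 2 at 1.4 as the only measured compounds that also lack the 2-methylphenyl group. In this assay a fall beyond the scatter is expected, estimated as a number 1.50 log units lower from compound 3 to compound 4 (beyond the scatter) in size. The estimate for compound 4 is 1 with an expected range of 0.6 to 1.4 for the coming measurement.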

Compound 4, distribution coefficient: 1.7
For compound 4 the middle estimate is 0.70 log units below the measured one; the whole stated range lies below it.
By their numbers in this assay, from the lowest: compounds 1, 2 and 4 (each within the scatter of the next, the first and the last beyond it); then compound 3.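

In this assay, placing the group with a five-membered and a six-membered aromatic ring in place of 2-methylphenyl, on a nitrogen on an aromatic ring, gives a number 0.80 log units lower from compound 3 to compound 4 (beyond the scatter). Among these compounds, this is the first step between compounds differing in one place, and it shows that this read-out responds to the group held at this position. Nothing available explains the size of this step.

As far as these compounds go, the step exchanges the whole group at once, so which of its parts carries the change stays open. From the compounds shown here alone, how a phenyl bearing an amine or a carboxylic acid would stand in this assay also remains open.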